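A few compounds are considered here, and "the series" means these few. Any claim that something is new, unique, unknown or untested is made for them only; others in the source may bear on it.

In a functional assay on NCI-H522 cells (Homo sapiens) for cytotoxicity, with a stated time of 3 days (on this read-out higher numbers stand for weaker inhibition and lower numbers for stronger inhibition), compound 1 `C#Cc1nc2ccccc2[se]1` gives 2170 nM and compound 2 `C=Cc1nc2ccccc2n1C` gives 2340 nM. Among the compounds with values here, these two values lie within the usual scatter of each other, so compound 2 stands level with compound 1 on the numbers so far. Compound 3 `Cn1cnc2ccccc21` has not yet been measured in this assay. It has hydrogen in place of vinyl on an aromatic carbon. Within the data shown here, no step between measured compounds is available, so the expectation rests on the structural change and on compound 2 at 2340 nM, which still carries vinyl on that carbon. Weaker inhibition, beyond the scatter, is expected for the loss of vinyl, though this is uncertain with so few data. The expected size is a step of a 6.4-fold higher number from compound 2 to compound 3 (0.81 log units; beyond the scatter). The estimated value for compound 3 is 15000 nM, with an expected range of 4000 nM to 60000 nM.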

Compound 3, half-maximal inhibitory concentration: > 40000 nM
Compound 3: no number, only a limit (the forecaster's own chance of this, stated with the estimate: 30%); middle value at least 2.6-fold (0.42 log units) away from the limit.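

In this assay, within the data shown here, hydrogen in place of vinyl on an aromatic carbon between two ring nitrogen atoms comes with an at least 17-fold higher number from compound 2 to compound 3 (1.23 log units; beyond the scatter), the first single change that can be read, and it shows that inhibition at this level depends on the vinyl at this position. Compound 3 gives > 40000 nM, which is a limit of the assay and not a number. The step therefore sets only a lower bound on what the vinyl contributes, and its full size stays unknown because compound 3 sits at the limit: the limit of > 40000 nM in this assay, at which 1 of the 3 values shown sits.

Going by these compounds, whether ethyl, an amine or a longer chain on this carbon would keep the inhibition of compound 2 stays open. Compound 1 differs from compound 2 in more than one place, so it does not settle what this position tolerates.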